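Hydroxyl for Fluorine on the Hydrazone Aryl Ring

A few compounds are considered here, and "the series" means these few. Any claim that something is new, unique, unknown or untested is made for them only; others in the source may bear on it.

In a functional assay on MKN-45 cells (Homo sapiens) for cytotoxicity, read by MTT assay, with a stated time of 72 h (a higher number here means a weaker inhibitor, a lower number a stronger inhibitor), compound 3 `CN(C)CCn1cnnc1-c1cc(Oc2ccc(NC(=O)N/N=C/c3ccc(F)cc3F)cc2F)ccn1` gives 810 nM, the highest of the two numbers shown, yet compound 1 `CN(C)CCn1cnnc1-c1cc(Oc2ccc(NC(=O)N/N=C/c3c[nH]c4ccccc34)cc2F)ccn1` with 790 nM sits so close that the two cannot be told apart, as a 1.0-fold higher number from compound 1 to compound 3 (0.01 log units; within the scatter) shows. For the measured compounds named here, compound 2 `Cn1ncnc1-c1cc(Oc2ccc(NC(=O)N/N=C/c3ccccc3)cc2F)ccn1` returns only a limit of the assay, > 100000 nM, and differs from compound 1 in two places, so its reading cannot be pinned to either change; it is the one reading at the limit of > 100000 nM in this assay, at which 1 of the 3 values shown sits.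

Compound 4 `CN(C)CCn1cnnc1-c1cc(Oc2ccc(NC(=O)N/N=C/c3ccc(O)cc3O)cc2F)ccn1` is the unmeasured partner of compound 3, differing by 2,4-dihydroxyphenyl in place of 2,4-difluorophenyl on a carbon with a double bond to nitrogen. Going by the values given here, the only measured step on that carbon, a 1.0-fold higher number from compound 1 to compound 3 (0.01 log units; within the scatter), stays within the scatter, and no measured pair isolates the entry of hydroxyl groups. The author therefore expects the step of a 1.9-fold higher number from compound 3 to compound 4 (0.27 log units; within the scatter) to be modest and, if anything, toward a higher number. For compound 4 the estimate is 1500 nM, with a range from 400 nM to 6000 nM.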

Compound 4, half-maximal inhibitory concentration: 2860 nM
Compound 4: middle estimate off by 1.9-fold (0.28 log units), on the low side, and the stated range covers the measured number.
By their numbers in this assay, from the lowest: compounds 1 and 3 (each within the scatter of the next); then compound 4. At a limit, above all of these: compound 2.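

In this assay, for the compounds shown here, the carbon with a double bond to nitrogen proves sensitive to its substituent for the first time: 2,4-dihydroxyphenyl in place of 2,4-difluorophenyl gives a 3.5-fold higher number from compound 3 to compound 4 (0.55 log units; beyond the scatter), whereas the earlier exchange of 1H-indol-3-yl for 2,4-difluorophenyl gave only a 1.0-fold higher number from compound 1 to compound 3 (0.01 log units; within the scatter). The same shift appears against the indole partner, with 2,4-dihydroxyphenyl in place of 1H-indol-3-yl giving a 3.6-fold higher number from compound 1 to compound 4 (0.56 log units; beyond the scatter). Nothing among the data shown accounts for this step.

The compounds shown leave open whether a single hydroxyl group would give the same step as two, or whether methoxy groups or an amine on the same aromatic ring would do so. Nor do they show how an unsubstituted phenyl on this carbon would read with the rest of compound 3 unchanged.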